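A few compounds are considered here, and "the series" means these few. Any claim that something is new, unique, unknown or untested is made for them only; others in the source may bear on it.

Measured so far:

Compound 1, `Cc1cccc(C2CC(c3ccc(Oc4ccccc4)cc3)=NN2c2ccc(S(N)(=O)=O)cc2)c1`; in an ADME assay on BHK-21 cells (Mesocricetus auratus) for cytotoxicity, read by MTT assay, with a stated time of 72 h (a lower number here means that less compound is tolerated, a higher number that more compound is tolerated), compound 1 gives 8000 nM.
Compound 2, `Cc1cccc(C2CC(c3ccc(OCc4ccccc4)cc3)=NN2c2ccc(S(N)(=O)=O)cc2)c1`; in this assay compound 2 gives 8000 nM.

Compound 2 stands level with compound 1 on these numbers: the step of no change at the digits printed from compound 1 to compound 2 (within the scatter), benzyl in place of phenyl on an oxygen on an aromatic ring, left the read-out unchanged within the scatter. Compound 3, `NS(=O)(=O)c1ccc(N2N=C(c3ccc(OCc4ccccc4)cc3)CC2c2cccc(Cl)c2)cc1`, is the next compound. It differs from compound 2 by chloro in place of methyl on an aromatic carbon. For the measured compounds named here, no measured step swaps chloro for methyl on an aromatic carbon, so the only guidance is that the one change tried so far, at the oxygen, moved nothing. Going by the values given here, with no step bearing directly on this exchange, no step beyond the scatter is expected in this assay, in either direction. Compound 3 is therefore estimated at 8000 nM, with a range from 4000 nM to 16000 nM, meaning an expected step of no change at the digits printed from compound 2 to compound 3 (within the scatter).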

Compound 3, half-maximal cytotoxic concentration: 45000 nM
The estimate for compound 3 lay 5.6-fold (0.75 log units) below the measured number; measured number outside the range, above it.
By their numbers in this assay, from the lowest: compounds 1 and 2 (each within the scatter of the next); then compound 3.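

In this assay, the exchange of 3-methylphenyl for 3-chlorophenyl gives a clear move (a 5.6-fold higher number from compound 2 to compound 3 (0.75 log units; beyond the scatter)), so more compound is tolerated with chloro than with methyl at this place. The earlier change at the oxygen left the number flat (no change at the digits printed from compound 1 to compound 2 (within the scatter)), so this aromatic carbon, meta to a large group, is the first place shown where a swap of one heavy atom moves the read-out beyond the scatter. Nothing available explains why this single exchange has this effect.

Going by these compounds, whether the same exchange would have the same effect with phenyl on the oxygen, as in compound 1, remains open. So does what an amine, a carboxylic acid or a longer chain at this place would do to the number.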